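This account rests on a few compounds, and the source may have more. Where it says the series, first, only, none or still open, it means among the compounds named here.

Working notes on the shared core of compound 1, which is `COc1cc(-c2nccn2C(C)C)cc(OC)c1OC`. In a functional assay on HCT-15 cells (Homo sapiens) for antiproliferative activity, read by MTT assay, with a stated time of 72 h (on this read-out higher numbers stand for weaker inhibition and lower numbers for stronger inhibition), compound 1 gives only a limit of the assay, > 100000 nM, so no number is known for it. Compound 1 therefore stands at the limit of > 100000 nM in this assay, at which 2 of the 3 values shown sit, and cannot be placed against the other values beyond that. Compound 2, `COc1cc(-c2nccn2-c2ccc3sccc3c2)cc(OC)c1OC`, carries an aromatic group on the same ring nitrogen and gives 3300 nM in this assay. Compound 3, `COc1cc(-c2nccn2-c2cccc([N+](=O)[O-])c2)cc(OC)c1OC`, also carries an aromatic group there; in this assay compound 3 gives only a limit, > 100000 nM. The two aromatic replacements thus go opposite ways, and no trend among them can be claimed.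

Compound 4 is `COc1ccc(-n2ccnc2-c2cc(OC)c(OC)c(OC)c2)cc1`. Compared with compound 1 the change is 4-methoxyphenyl in place of isopropyl on an aromatic nitrogen. For the measured compounds named here, because compound 1 stands at the limit of > 100000 nM in this assay, at which 2 of the 3 values shown sit, no measured step from it exists, and the expectation rests on compound 2 and compound 3 alone. For compound 4 a step of an at least 5.0-fold lower number from compound 1 to compound 4 (0.69 log units; beyond the scatter) toward stronger inhibition is expected, with real uncertainty. Compound 4 is estimated at 20000 nM, between 1500 nM and 100000 nM.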

Compound 4, half-maximal inhibitory concentration: 1300 nM
Compound 4: the middle estimate sits 15-fold (1.19 log units) above what was measured; measured number outside the range, below it.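

For the compounds shown here, on this aromatic nitrogen, 4-methoxyphenyl in place of isopropyl gives an at least 76-fold lower number from compound 1 to compound 4 (1.88 log units; beyond the scatter) in this assay, the only step that can be read so far. Its size stands only as a bound, because compound 1 gives a limit and no number: the limit of > 100000 nM in this assay, at which 2 of the 4 values shown sit. Compound 4 gives 1300 nM and compound 2 gives 3300 nM, so an aromatic group on this nitrogen can bring a measured number, though compound 3 goes against any claim that every aromatic group does so.

The compounds shown leave open how much of the step belongs to the six-membered aromatic ring and how much to its methoxy group, which a plain phenyl would separate. Also open, on these data alone, is how a longer chain on this nitrogen, or an amine or a carboxylic acid on the aromatic ring, would read in this assay.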